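From ureido to methylsulfanyl on a sulfur-linked chain

This account rests on a few compounds, and the source may have more. Where it says the series, first, only, none or still open, it means among the compounds named here.

Of the compounds shown here, two sharing one core have been measured in a functional assay on HT cells (Homo sapiens) for antiproliferative activity, read by fluorescence, with a stated time of 72 h; a higher number here means a weaker inhibitor of growth, a lower number a stronger inhibitor of growth. There, compound 1 `CC(C)c1n[nH]c2c(NCc3ccc(-c4ccccn4)cc3)nc(SCC(C)(C)N)nc12` gives 85 nM, and compound 2 `CC(C)c1n[nH]c2c(NCc3ccc(-c4ccccn4)cc3)nc(SCCNC(N)=O)nc12` gives 240 nM, the higher number of the pair and so the weaker inhibitor of growth. Compound 3 `CSCCSc1nc(NCc2ccc(-c3ccccn3)cc2)c2[nH]nc(C(C)C)c2n1` differs from compound 2 only at the far end of its chain: methylsulfanyl in place of ureido on a saturated chain carbon, two bonds along the chain from a sulfur. Methylsulfanyl stands in place of ureido on a saturated chain carbon, two bonds along the chain from a sulfur. Among the compounds with values here, the only measured step that bears on this is a 2.8-fold higher number from compound 1 to compound 2 (0.45 log units; beyond the scatter), a modest change that also alters this chain. Within the data shown here, one step is thin evidence, and no measured compound carries methylsulfanyl. In this assay, little change beyond the scatter is therefore expected, with a slightly higher number somewhat more likely than a lower one. The expected step is a 1.3-fold higher number from compound 2 to compound 3 (0.10 log units; within the scatter). Compound 3 is estimated at 300 nM, with an expected range from 100 nM to 800 nM.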

Compound 3, concentration for 50% growth inhibition: 975 nM
The estimate for compound 3 lay 3.3-fold (0.51 log units) below the measured number; the measured number lies above the stated range.
By their numbers in this assay, from the lowest: compound 1; then compound 2; then compound 3.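

In this assay, within the data shown here, the change at the far end of this chain proves larger than the one earlier step suggested: methylsulfanyl in place of ureido gives a 4.1-fold higher number from compound 2 to compound 3 (0.61 log units; beyond the scatter) and removes both hydrogen-bond donors of ureido, as methylsulfanyl has 0. Measured against the 1-amino-1-methylethyl chain end, the gap is wider still, with an 11-fold higher number from compound 1 to compound 3 (1.06 log units; beyond the scatter) as a large step, which makes compound 3 the weakest inhibitor of growth of the three. The information at hand offers no explanation for either step.

Three chain ends are too few to show which feature of the chain end tracks with growth inhibition. From the compounds shown here alone, it remains open whether a chain ending in a hydroxyl group or a carboxylic acid, or a longer chain carrying an amine, would sit nearer compound 1 or compound 3.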